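Trimming the Amine Side Chain of Compound 3

A few compounds are considered here, and "the series" means these few. Any claim that something is new, unique, unknown or untested is made for them only; others in the source may bear on it.

Measured in a physicochemical assay for solubility, read by nephelometry, measured as kinetic solubility, with a stated time of 30 min; a higher number here means a more soluble compound, a lower number a less soluble compound:
compound 1 `N[C@H]1CC[C@@H](Oc2ccc([C@H]3CC[C@]4(CC3)OOC3(O4)C4CC5CC(C4)CC3C5)cc2)CC1` gives 25 ug/mL
compound 2 `c1cc([C@H]2CC[C@]3(CC2)OOC2(O3)C3CC4CC(C3)CC2C4)ccc1OCC1CCNCC1` gives 12.5 ug/mL
compound 3 `CC1(C)CC(O)(COc2ccc([C@H]3CC[C@]4(CC3)OOC3(O4)C4CC5CC(C4)CC3C5)cc2)CC(C)(C)N1` gives > 100 ug/mL, which is a limit of the assay and not a number.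

Compound 3 therefore stands at the top of the three, sitting at the limit of > 100 ug/mL in this assay, at which 1 of the 3 values shown sits, so how far it actually lies above the other two is not known. The steps that lead to it are an at least 4.0-fold higher number from compound 1 to compound 3 (0.60 log units; beyond the scatter) and an at least 8.0-fold higher number from compound 2 to compound 3 (0.90 log units; beyond the scatter), while the step of a 2.0-fold lower number from compound 1 to compound 2 (0.30 log units; within the scatter) separates the two lower compounds.

Compound 4 `NCCCCOc1ccc([C@H]2CC[C@]3(CC2)OOC2(O3)C3CC4CC(C3)CC2C4)cc1` differs from compound 3 by 3-aminopropyl in place of 4-hydroxy-2,2,6,6-tetramethylpiperidin-4-yl on a saturated chain carbon bound to an oxygen on an aromatic ring. This change moves away from the group that carried compound 3 to the limit, back towards a simple primary amine on a flexible chain, closer in kind to the 4-aminocyclohexyl of compound 1. The two steps that reached compound 3 were both at least modest rises, so a fall of comparable size in this assay is expected, with the true size uncertain because compound 3 only gives the limit > 100 ug/mL.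

Compound 4 is thus expected to give about 30 ug/mL, with a range from 10 ug/mL to 90 ug/mL. That corresponds to an expected at least 3.3-fold lower number from compound 3 to compound 4 (0.52 log units; beyond the scatter).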

Compound 4, solubility: 50 ug/mL
The estimate for compound 4 lay 1.7-fold (0.22 log units) below the measured number; measured number inside the range.
By their numbers in this assay, from the lowest: compounds 2, 1 and 4 (each within the scatter of the next, the first and the last beyond it). At a limit, above all of these: compound 3.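

In this assay, 3-aminopropyl in place of piperidin-4-yl at this saturated chain carbon gives a 4.0-fold higher number from compound 2 to compound 4 (0.60 log units; beyond the scatter), so at this position an open chain carrying a primary amine stands clear of the ring-bound amine of the piperidin-4-yl group. The same side chain, read as 4-aminobutyl in place of 4-aminocyclohexyl on the oxygen on the aromatic ring, gives a 2.0-fold higher number from compound 1 to compound 4 (0.30 log units; within the scatter), so this assay does not tell these two side chains apart. Taking out 4-hydroxy-2,2,6,6-tetramethylpiperidin-4-yl gives an at least 2.0-fold lower number from compound 3 to compound 4 (0.30 log units; that floor lies within the scatter), a floor that lies within the scatter, so the open chain is not shown to differ from that group, and the value of compound 3 is a limit of the assay and not a number: the limit of > 100 ug/mL in this assay, at which 1 of the 4 values shown sits.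

On these data alone, how far compound 3 truly lies above the open-chain compound therefore stays unknown. As far as these compounds go, it also remains open whether a shorter or longer chain, or a dimethylamino group in place of the primary amine, would hold the reading of compound 4, and whether the hydroxyl group or the four methyl groups of compound 3 matter more.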